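Replacing the thiophene on the shared core with a cyclopentene

The source may report more compounds than this note shows. Statements on the series, on what has been measured and on what is new or still open speak of the compounds shown alone.

Measured so far:
compound 1, `CC(C)C[C@H](N)CN(C(=O)[C@@H]1C[C@H]1c1ccccc1)c1ccc(-c2cccnc2)cc1`: 10000 nM
compound 2, `CC(C)C[C@H](N)CN(C(=O)[C@@H]1C[C@H]1c1ccccc1)c1ccc(-c2cccs2)cc1`: 1500 nM

In a functional assay for agonist activity at G protein-coupled receptor 88 (Homo sapiens), read by HTRF and cAMP accumulation (on this read-out higher numbers stand for an effect only at larger amounts of compound and lower numbers for an effect already at smaller amounts), compound 2 stands lowest of the two numbers; its nearest neighbour is compound 1, separated by a 6.7-fold lower number from compound 1 to compound 2 (0.82 log units; beyond the scatter). Compound 3, `CC(C)C[C@H](N)CN(C(=O)[C@@H]1C[C@H]1c1ccccc1)c1ccc(C2=CCCC2)cc1`, differs from compound 2 in one place: cyclopent-1-en-1-yl in place of thiophen-2-yl on an aromatic carbon. For the measured compounds named here, the single measured step, a 6.7-fold lower number from compound 1 to compound 2 (0.82 log units; beyond the scatter), exchanged one five-membered aromatic ring for another and moved the number modestly. Going by the values given here, the present change instead exchanges that aromatic ring for a non-aromatic one, and no measured step mirrors it, so a modest move upward is expected, a 2.0-fold higher number from compound 2 to compound 3 (0.30 log units; within the scatter). Compound 3 is estimated at 3000 nM, within 800 nM to 12000 nM.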

Compound 3, half-maximal effective concentration: 1200 nM
The estimate for compound 3 lay 2.5-fold (0.40 log units) above the measured number, within the range that was stated.
By their numbers in this assay, from the lowest: compounds 3 and 2 (each within the scatter of the next); then compound 1.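

In this assay, the aromatic thiophen-2-yl gives way to the non-aromatic, carbon-only cyclopent-1-en-1-yl with a 1.3-fold lower number from compound 2 to compound 3 (0.10 log units; within the scatter) as the whole step, so on this aromatic carbon neither a sulfur atom nor an aromatic ring is required to keep the number. Cyclopent-1-en-1-yl in place of pyridin-3-yl gives an 8.3-fold lower number from compound 1 to compound 3 (0.92 log units; beyond the scatter) on the same core. Nothing available explains either step.

Open, as far as these compounds go, is whether the fully saturated cyclopentyl, or a cyclopentene bearing an amine, would hold the number at this position.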